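Carboxypiperidinyl replacement in the trypsin counter-screen

The compounds below may be only part of what the source reports. "The series", "measured", "known", "first", "only" and "open" are said of these compounds alone.

Compound 1 `CCOC(=O)C1CCN(c2ccc(N3C[C@H](CNC(=O)c4ccc(Cl)s4)OC3=O)cc2)C(=O)C1` and compound 2 `CCOC(=O)C1CCCCN1c1ccc(N2C[C@H](CNC(=O)c3ccc(Cl)s3)OC2=O)cc1` share a core and differ only in the substituent on an aromatic carbon of a six-membered aromatic ring of carbon only. In an assay on isolated protein for inhibition of Trypsin (Homo sapiens), read by spectrophotometry, with a stated time of 15 min (on this read-out higher numbers stand for weaker inhibition and lower numbers for stronger inhibition), compound 1 gives only a limit, > 100000 nM. In this assay compound 2 likewise gives only a limit, > 100000 nM. Compound 2 thus sits at the limit of > 100000 nM in this assay, at which 2 of the 2 values shown sit. Compound 3 `O=C(NC[C@H]1CN(c2ccc(N3CCCC(C(=O)O)C3)cc2)C(=O)O1)c1ccc(Cl)s1` carries 3-carboxypiperidin-1-yl in place of 2-(ethoxycarbonyl)piperidin-1-yl on an aromatic carbon. Going by the values given here, no measured step exists to read a direction from, and a step that the limit leaves unreadable from compound 2 to compound 3 is expected to be none beyond the scatter. Compound 3 is estimated at 150000 nM, within 50000 nM to 500000 nM.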

Compound 3, inhibition constant: > 100000 nM
Compound 3: no number, only a limit; the forecaster's own chance of this, stated with the estimate: 85%; the middle value is on the limit's open side.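

The step from compound 2 to compound 3 cannot be read, as both values are limits: the limit of > 100000 nM in this assay, at which 3 of the 3 values shown sit.

Still open, going by these compounds, is how compound 1, compound 2 and compound 3 rank in this assay, and what size of step 3-carboxypiperidin-1-yl makes in place of 2-(ethoxycarbonyl)piperidin-1-yl.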